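Biphenyl amide series: pyridin-2-yl in place of phenyl

This account rests on a few compounds, and the source may have more. Where it says the series, first, only, none or still open, it means among the compounds named here.

Three compounds of the series have a number in a functional assay on MV4-11 cells (Homo sapiens) for antiproliferative activity, with a stated time of 6 days, tested at 1.56 uM; on this read-out higher numbers stand for a stronger effect at the one concentration tested and lower numbers for a weaker effect. Compound 1 `CNC(=O)N1CCCc2ccc(NC(=O)c3ccc(-c4ccccc4)cc3)cc21` gives 19.7% and stands at the top of the three numbers. Compound 3 `CNC(=O)N1CCCc2ccc(NC(=O)c3ccccc3-c3ccccc3)cc21` gives 10.7% in this assay, a number that lies within the usual scatter of the number for compound 1, so no order between the two can be read. Compound 2 `CNC(=O)N1CCCc2ccc(NC(=O)c3cccc(-c4ccn(S(C)(=O)=O)n4)c3)cc21` gives 4.03% in this assay, a number that sits beyond the scatter under the number for compound 1, so compound 2 reads as weaker at the one concentration tested.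

Compound 4 `CNC(=O)N1CCCc2ccc(NC(=O)c3ccc(-c4ccccn4)cc3)cc21` is not yet measured. The change from compound 1 to compound 4 is pyridin-2-yl in place of phenyl on an aromatic carbon, seated on an aromatic carbon of a six-membered aromatic ring of carbon only, para to a large group. Going by the values given here, no measured pair carries this same change, so its size has to be guessed from the spread of the three numbers alone. A step of small size, downward or none beyond the scatter, is expected. The number for compound 4 in this assay is estimated at 15%, with a range from 3% to 32%, which would mean an expected step of a number 4.7 percentage points lower from compound 1 to compound 4 (within the scatter).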

Compound 4, a percentage reported as inhibition, at one concentration (the size of the read-out at that concentration, not a potency): 32%
For compound 4 the middle estimate is 17 percentage points below the measured one; low and high end bracket the measured number.
By their numbers in this assay, from the lowest: compounds 2, 3 and 1 (each within the scatter of the next, the first and the last beyond it); then compound 4.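

In this assay, going by these compounds alone, the step of a number 12.3 percentage points higher from compound 1 to compound 4 (beyond the scatter) is the first change that can be read at a single place: pyridin-2-yl in place of phenyl on an aromatic carbon, para to a large group, with the rest of the structure kept. It shows that the number at this position responds to a change within the ring itself, since the heavy-atom count stays at 6 and the one difference is a ring nitrogen in place of a ring carbon, which adds a hydrogen-bond acceptor to a group that had none. No measurement here bears on why the number rises, so the step stands without an explanation.

From the compounds shown here alone, whether the ring nitrogen must sit where it does in pyridin-2-yl stays open, as pyridin-3-yl, pyridin-4-yl and pyrimidin-2-yl at the same place would be needed to tell, and so does the effect of a methoxy group or an amine on the new ring. The read-out also comes from one concentration, so it gives no potency for any of these compounds, and how the step would look across a range of concentrations is unknown.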